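This account rests on a few compounds, and the source may have more. Where it says the series, first, only, none or still open, it means among the compounds named here.

Among the compounds with values here, in a functional assay on MCF7 cells (Homo sapiens) for antiproliferative activity, read by MTT assay, with a stated time of 24 h (a higher number here means a weaker inhibitor, a lower number a stronger inhibitor), compound 2 `CCCCc1oc2ccccc2c1C(=O)c1ccc(OCCCC(=O)N2CCCC2)cc1` gives 23500 nM, the only exact number so far. Compound 3 `CCCCc1oc2ccccc2c1C(=O)c1ccc(OCCCC(=O)N2CCOCC2)cc1` differs from it in one place, with morpholin-4-yl in place of pyrrolidin-1-yl on a carbonyl carbon. Within the data shown here, one measured step bears on this change: an at least 2.1-fold lower number from compound 1 to compound 2 (0.32 log units; beyond the scatter), with 2-((pyrrolidin-1-yl)carbonyl)ethyl in place of (piperidin-1-yl)carbonyl. That step alters more than the ring and starts from a limit, so it is only a loose guide (the limit of > 50000 nM in this assay, at which 1 of the 2 values shown sits). Compound 3 has a six-membered non-aromatic ring, and so does compound 1 `CCCCc1oc2ccccc2c1C(=O)c1ccc(OCC(=O)N2CCCCC2)cc1`. Compound 1 reads > 50000 nM, and this is a limit of the assay. The expected change is a 1.3-fold higher number from compound 2 to compound 3 (0.11 log units; within the scatter), leaning towards a higher number but not clearly beyond the scatter. For compound 3 the estimate is 30000 nM, with an expected range of 15000 nM to 55000 nM.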

Compound 3, half-maximal inhibitory concentration: 41200 nM
Beside the measured number, compound 3's estimate is 1.4-fold (0.14 log units) below it; the range from low to high includes it.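

In this assay, the chain now stays fixed while only the ring on the carbonyl carbon changes, and the result is a 1.8-fold higher number from compound 2 to compound 3 (0.24 log units; within the scatter). This position therefore shows no clear response to morpholin-4-yl in place of pyrrolidin-1-yl, even though the entering ring carries a hydrogen-bond acceptor and the leaving ring has none. The other new step, an at least 1.2-fold lower number from compound 1 to compound 3 (0.08 log units; that floor lies within the scatter), changes more than the ring, and compound 1 reads a limit of the assay rather than a number, so that step sets no true size: the limit of > 50000 nM in this assay, at which 1 of the 3 values shown sits.

On these data alone, how an open-chain dimethylamino group or a piperazin-1-yl ring would read on this carbonyl carbon remains open. The compounds shown also leave the effect of chain length unseparated from that of the ring, since no pair among them differs in the chain alone.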